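Urea to amide swap on the shared core

The source may report more compounds than this note shows. Statements on the series, on what has been measured and on what is new or still open speak of the compounds shown alone.

Compound 1 `O=C(Nc1cccc(-n2cc(-c3ccncc3)c(-c3cc(O)cc(Cl)c3)n2)c1)Nc1ccc(Cl)c(Cl)c1` gives 97% in a functional assay on HOP-62 cells (Homo sapiens) for inhibition, read by sulforhodamine B assay, with a stated time of 48 h, tested at 0.1 uM; a higher number here means a weaker effect of the compound at the concentration tested, a lower number a stronger effect. Within the data shown here, compound 2 `COc1cc(Cl)cc(-c2nn(-c3cccc(NC(=O)Nc4ccc(Cl)c(Cl)c4)c3)cc2-c2ccncc2)c1` gives 94% in this assay; the single measured step, a number 3 percentage points lower from compound 1 to compound 2 (within the scatter), leaves both within the scatter of each other, so neither stands apart. Compound 3 `COc1cc(Cl)cc(-c2nn(-c3cccc(NC(=O)c4cccc(C(F)(F)F)c4)c3)cc2-c2ccncc2)c1` carries the change (3-(trifluoromethyl)phenyl in place of (3,4-dichlorophenyl)amino on a carbonyl carbon). Among the measured compounds shown here, no measured step touches the carbonyl side, so nothing here bears on it; the one step known is small. The estimate is therefore a step of a number 1 percentage points lower from compound 2 to compound 3 (within the scatter), none beyond the scatter, and compound 3 is expected at 93%, between 75% and 100%.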

Compound 3, a percentage reported as activity, at one concentration (the size of the read-out at that concentration, not a potency): 101%
The estimate for compound 3 lay 8 percentage points below the measured number; the measured number lies above the stated range.
By their numbers in this assay, from the lowest: compounds 2, 1 and 3 (each within the scatter of the next).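

On the carbonyl carbon, 3-(trifluoromethyl)phenyl in place of (3,4-dichlorophenyl)amino gives a number 7 percentage points higher from compound 2 to compound 3 (within the scatter) in this assay. This position, unlike the oxygen substituent of the earlier step, is now shown to accept a change from a urea to an amide, with the loss of the donor counted on the leaving group, without a separable shift in the read-out. No measurement on hand offers an explanation for this.

It remains open whether a morpholine or a carboxylic acid on this carbonyl carbon would set a compound apart from the three shown.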